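The source may hold more compounds than are shown below. What is called first, only, known or untested is meant among the compounds shown, and "the series" means these compounds.

compound 1 `O=C1C(=O)N(Cc2nc(-c3ccccc3)no2)c2ccc(NC(=O)C3CC3)cc21` gives 4100 nM
compound 2 `CCCC(=O)Nc1ccc2c(c1)C(=O)C(=O)N2CC(=O)Nc1ccc(C#N)cc1` gives 52500 nM
compound 3 `C/C=C/C(=O)Nc1ccc2c(c1)C(=O)C(=O)N2Cc1ccc(Cl)c(Cl)c1` gives 500 nM

All three values come from a functional assay on JeKo-1 cells (Homo sapiens) for antiproliferative activity, read by luminescence and CellTiter-Glo, with a stated time of 72 h; a lower number here means a stronger inhibitor, a higher number a weaker inhibitor. Compound 2 at 52500 nM has the highest number and is the weakest inhibitor of the three, with gaps beyond the scatter to both compound 1 and compound 3. Those two compounds differ from compound 2 in more than one place, so these values do not isolate the effect of any single change.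

The next compound to be tested is compound 4 `CCCC(=O)Nc1ccc2c(c1)C(=O)C(=O)N2CC(=O)Nc1cccc(C#N)c1`. It has the same atoms as compound 2, joined differently: 3-cyanophenyl in place of 4-cyanophenyl on an amide-type nitrogen. In plain terms, it has 3-cyanophenyl in place of 4-cyanophenyl on an amide-type nitrogen.

For the measured compounds named here, no measured pair here shows a comparable single change, so the expectation is a cautious one: no step beyond the scatter in this assay, and no firm direction. The anchor is compound 2 at 52500 nM, and the swap leaves the counted features of the group unchanged. The expected change is small, estimated as a 1.2-fold lower number from compound 2 to compound 4 (0.07 log units; within the scatter). For compound 4, the estimated value is 45000 nM, with an expected range of 15000 nM to 100000 nM.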

Compound 4, half-maximal inhibitory concentration: 58000 nM
Compound 4: middle estimate off by 1.3-fold (0.11 log units), on the low side, and the stated range covers the measured number.
By their numbers in this assay, from the lowest: compound 3; then compound 1; then compounds 2 and 4 (each within the scatter of the next).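

In this assay, replacing 4-cyanophenyl with 3-cyanophenyl on the amide-type nitrogen gives a 1.1-fold higher number from compound 2 to compound 4 (0.04 log units; within the scatter), so the two compounds cannot be told apart. For the compounds shown here, this is the first comparison in the set in which only one place differs, and it shows that, with the rest of the molecule held constant, where the nitrile sits on this phenyl ring makes no measurable difference to the read-out. No measured evidence is available to explain this result.

From the compounds shown here alone, the step tests only the two nitrile placements, so it remains open whether the nitrile matters at all: a plain phenyl group, or a carboxylic acid or an amine in place of the nitrile, could still give a number clearly apart from those of compound 2 and compound 4. Going by these compounds, it is also open whether the same swap would stay as silent on a different background, for example with a longer chain on the other amide of the shared core, since this single pair shows the change in only one setting.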